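This account rests on a few compounds, and the source may have more. Where it says the series, first, only, none or still open, it means among the compounds named here.

Of the compounds shown here, three built on a shared core have been tested in an ADME assay on HFF cells (Homo sapiens) for cytotoxicity, read by MTT assay, with a stated time of 72 h; on this read-out higher numbers stand for weaker inhibition and lower numbers for stronger inhibition. Compound 1 `Cc1ccc(-c2cn(C/C=C3\OC(=O)C(OCc4ccccc4)=C3OCc3ccccc3)nn2)cc1` gives > 100000 nM, which is a limit of the assay and not a number. Compound 2 `CCCCCc1ccc(-c2cn(C[C@H](O)[C@H]3OC(=O)C(OCc4ccccc4)=C3OCc3ccccc3)nn2)cc1` gives > 100000 nM, again a limit rather than a number. Compound 3 `O=C1O/C(=C\Cn2cc(-c3cc(C(F)(F)F)cc(C(F)(F)F)c3)nn2)C(OCc2ccccc2)=C1OCc1ccccc1` gives > 100000 nM, also a limit. Compound 2 therefore stands exactly where everything else stands: the limit of > 100000 nM in this assay, at which 3 of the 3 values shown sit. Among the compounds with values here, no measured compound has given a number, so no step between measured compounds can be stated; the values of compounds 1, 2 and 3 show only that all three sit at the same limit.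

Compound 4 `O=C1O[C@H]([C@@H](O)Cn2cc(CNS(=O)(=O)c3ccc(Cl)cc3)nn2)C(OCc2ccccc2)=C1OCc1ccccc1` has not yet been measured. It differs from compound 2 in one place: (((4-chlorophenyl)sulfonyl)amino)methyl in place of 4-pentylphenyl on an aromatic carbon. No step beyond the scatter is expected from this change, because all three values shown sit at the limit of > 100000 nM in this assay, at which 3 of the 3 values shown sit, whatever group is carried on that aromatic carbon. Compound 4 is accordingly expected to give about 150000 nM in this assay, with a range from 50000 nM to 500000 nM. The expected step is then a step that the limit leaves unreadable from compound 2 to compound 4, and the most likely outcome is that compound 4 is again reported only as a limit.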

Compound 4, half-maximal inhibitory concentration: 20 nM
Beside the measured number, compound 4's estimate is 7500-fold (3.88 log units) above it; measured number outside the range, below it.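

In this assay, the group on this aromatic carbon of the five-membered ring proves decisive: putting (((4-chlorophenyl)sulfonyl)amino)methyl in place of 4-pentylphenyl gives an at least 5000-fold lower number from compound 2 to compound 4 (3.69 log units; beyond the scatter), a large move towards stronger inhibition. The earlier compounds shown here could not reveal this, since they gave no number to compare and so made the position look silent, and the true size of the step stays hidden too, since one end of it is a limit: the limit of > 100000 nM in this assay, at which 3 of the 4 values shown sit. Compound 4 is thus the first compound shown to give a number, which means that this scaffold is not inert towards these cells whatever it carries, and that a swap at this one place is enough to change the outcome completely.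

The change replaces the whole group at once, so the compounds shown leave open which part of it matters: the sulfonyl, the amino hydrogen, the chlorine or the methylene link. A carbonyl in place of the sulfonyl, or a fluorine or a methoxy group in place of the chlorine, would begin to separate these parts.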